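Extending the acetamide of compound 3 by one carbon

The compounds below may be only part of what the source reports. "The series", "measured", "known", "first", "only" and "open" are said of these compounds alone.

Three compounds share one core and were tested in an assay on NIH3T3 cells with melatonin receptor type 1A (Homo sapiens) as the target; a higher number here means a weaker inhibitor, a lower number a stronger inhibitor. Compound 1 `CCCC(=O)NC[C@@H]1C[C@H]1c1cccc2nc(CC)oc12` gives 0.05 nM in this assay. Compound 3 `CC(=O)NC[C@@H]1C[C@H]1c1cccc2nc(CCCCc3ccccc3)oc12` gives 0.05 nM, level with compound 1 at the digits reported and within the usual scatter of it. Compound 2 `CCCC1Nc2cccc([C@@H]3C[C@H]3CNC(=O)NCC)c2O1` gives 3.5 nM, a higher number that lies beyond the scatter from both of the others. Compound 4 `CCC(=O)NC[C@@H]1C[C@H]1c1cccc2nc(CCCCc3ccccc3)oc12` has not yet been measured in this assay. It differs from compound 3 in one place: methyl in place of hydrogen on a saturated chain carbon bound to a carbonyl carbon, so the acetamido group becomes a propanoylamino group. Going by the values given here, no step between measured compounds isolates this change. Compound 1, which carries a longer acyl chain on the same nitrogen together with a different substituent on the core, sits level with compound 3 in this assay, which is the only hint available. Compound 4 is therefore expected to stay within the scatter of compound 3, with the step from compound 3 to compound 4 estimated as no change at the digits printed from compound 3 to compound 4 (within the scatter). Compound 4 is expected to give about 0.05 nM in this assay, estimated between 0.02 nM and 0.15 nM.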

Compound 4, inhibition constant: 0.05 nM
The estimate for compound 4 equals the measured number at the digits printed; measured number inside the range.
By their numbers in this assay, from the lowest: compounds 1, 3 and 4 (each within the scatter of the next); then compound 2.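

In this assay, going by these compounds alone, a methyl in place of hydrogen on a saturated chain carbon bound to a carbonyl carbon gives no change at the digits printed from compound 3 to compound 4 (within the scatter) and is the first step in this set to isolate a change in the acyl group. Read with the rest of the structure held constant, it shows that going from acetyl to propanoyl leaves the affinity number at this place unmoved. No supporting data bear on why the number holds at this place.

As far as these compounds go, this single step covers only one added carbon, so it remains open whether a longer chain such as butanoyl or pentanoyl, or a branched group such as isobutanoyl, would also hold the number. Also open, from the compounds shown here alone, is how a cyclopropyl group or a terminal amine on the acyl chain would read.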